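From 3,4-dimethylphenyl to 4-iodophenyl on the shared core

The source may report more compounds than this note shows. Statements on the series, on what has been measured and on what is new or still open speak of the compounds shown alone.

Three measured compounds share one core and differ only in the aromatic group on an amine nitrogen: compound 1 `CCCc1ccc(NC2=CC(=O)c3nc4n(c3C2=O)[C@H]2OC[C@@H](O)[C@H]2OC4)cc1`, compound 2 `COc1ccccc1NC1=CC(=O)c2nc3n(c2C1=O)[C@H]1OC[C@@H](O)[C@H]1OC3` and compound 3 `Cc1ccc(NC2=CC(=O)c3nc4n(c3C2=O)[C@H]2OC[C@@H](O)[C@H]2OC4)cc1C`. In a functional assay on MCF7 cells (Homo sapiens) for inhibition, read by sulforhodamine B assay (a higher number here means a weaker inhibitor, a lower number a stronger inhibitor), compound 3 gives 2080 nM, the lower of the two actual numbers, while compound 1 gives 4660 nM. Compound 2 gives > 4000 nM, which is a limit of the assay and not a number.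

Compound 4 `O=C1C=C(Nc2ccc(I)cc2)C(=O)c2c1nc1n2[C@H]2OC[C@@H](O)[C@H]2OC1` has not yet been measured. It carries 4-iodophenyl in place of 3,4-dimethylphenyl on an amine nitrogen.

Within the data shown here, no measured step involves iodine, so the guidance is indirect. The readable exchange among these groups is modest: a 2.2-fold lower number from compound 1 to compound 3 (0.35 log units; beyond the scatter). The other step that reaches compound 3 is an at least 1.9-fold lower number from compound 2 to compound 3 (0.28 log units; that floor lies within the scatter), and it adds little. Resting on compound 1 and that modest first step, a small move to a higher number is expected in this assay, probably not clearly beyond the scatter. The expected change is a 1.4-fold higher number from compound 3 to compound 4 (0.16 log units; within the scatter). For compound 4 the estimated value is 3000 nM, with an expected range from 1200 nM to 7000 nM.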

Compound 4, half-maximal inhibitory concentration: 2230 nM
The estimate for compound 4 lay 1.3-fold (0.13 log units) above the measured number; the measured number falls inside the stated range.
By their numbers in this assay, from the lowest: compounds 3 and 4 (each within the scatter of the next); then compound 1.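

In this assay, 4-iodophenyl in place of 3,4-dimethylphenyl on the amine nitrogen gives a 1.1-fold higher number from compound 3 to compound 4 (0.03 log units; within the scatter), so at this position a single iodine on the ring and two methyl groups on it read the same, even though the two groups differ in their atoms. Iodo in place of propyl on an aromatic carbon gives a 2.1-fold lower number from compound 1 to compound 4 (0.32 log units; beyond the scatter), which means the 4-propylphenyl compound, compound 1, now stands apart from two different groups instead of one, though only by a modest step. The reading against the 2-methoxyphenyl group is an at least 1.7-fold lower number from compound 2 to compound 4 (0.25 log units; that floor lies within the scatter), which settles no order between the two.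

Compound 2 remains a limit and not a number, so the true size of its gap to the others stays unread: the limit of > 4000 nM in this assay, at which 1 of the 4 values shown sits. Whether a plain phenyl, a 4-aminophenyl or a 4-carboxyphenyl group on the same nitrogen would stay level with compound 3 and compound 4 or move away from them is open, and the numbers alone give no reason for any of these gaps.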